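Replacing 3-aminophenyl with 4-methoxyphenyl on the shared core

The compounds below may be only part of what the source reports. "The series", "measured", "known", "first", "only" and "open" are said of these compounds alone.

In a functional assay on SGC-7901 cells (Homo sapiens) for antiproliferative activity, read by MTT assay, with a stated time of 72 h (a lower number here means a stronger inhibitor, a higher number a weaker inhibitor), compound 3 `COc1cc(-n2cnc3ccc(-c4cccc(N)c4)cc32)cc(OC)c1OC` gives 21 nM and stands lowest of the three measured compounds. Compound 2 `COc1ccc(-c2ccc3ncn(-c4cc(OC)c(OC)c(OC)c4)c3c2)cc1F` gives 430 nM and compound 1 `COc1cc(-n2cnc3ccc(-c4ccc(C)cc4F)cc32)cc(OC)c1OC` gives 5650 nM in the same test. Compound 4 `COc1ccc(-c2ccc3ncn(-c4cc(OC)c(OC)c(OC)c4)c3c2)cc1` is unmeasured and has 4-methoxyphenyl in place of 3-aminophenyl on an aromatic carbon. The nearest evidence is compound 2, whose 3-fluoro-4-methoxyphenyl group resembles the entering group. The large step to 3-aminophenyl there (a 20-fold lower number from compound 2 to compound 3 (1.31 log units; beyond the scatter)) is joined by a larger one (a 270-fold lower number from compound 1 to compound 3 (2.43 log units; beyond the scatter)), so leaving 3-aminophenyl is expected to raise the number in this assay by a large step. The expected move is a 9.5-fold higher number from compound 3 to compound 4 (0.98 log units; beyond the scatter) and would lie beyond the scatter. Compound 4 is estimated at 200 nM with an expected range from 50 nM to 800 nM for now.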

Compound 4, half-maximal inhibitory concentration: 82 nM
The estimate for compound 4 lay 2.4-fold (0.39 log units) above the measured number, and the stated range covers the measured number.
By their numbers in this assay, from the lowest: compound 3; then compound 4; then compound 2; then compound 1.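

In this assay the 4-methoxyphenyl group comes closer to 3-aminophenyl at this position than the earlier groups did, though it does not match it, with a 3.9-fold higher number from compound 3 to compound 4 (0.59 log units; beyond the scatter) as the step. Hydrogen in place of fluoro alone gives a 5.2-fold lower number from compound 2 to compound 4 (0.72 log units; beyond the scatter) and so isolates a single-atom effect on the number, while a 69-fold lower number from compound 1 to compound 4 (1.84 log units; beyond the scatter) sets 4-methoxyphenyl far apart from 2-fluoro-4-methylphenyl. No evidence is available that explains any of these steps.

Still open, as far as these compounds go, is whether the advantage of 3-aminophenyl belongs to the amine or to its place on the ring. A 4-aminophenyl or 3-methoxyphenyl group at this position would separate the two.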